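Cytotoxicity of biaryl nitrobenzamides: replacing benzothiazolyl with phenyl

The compounds below may be only part of what the source reports. "The series", "measured", "known", "first", "only" and "open" are said of these compounds alone.

Compound 1 `O=C(Nc1ccc(-c2nc3ccccc3s2)cc1)c1cc([N+](=O)[O-])ccc1Cl` was tested in an ADME assay on BJ cells (Homo sapiens) for cytotoxicity, with a stated time of 72 h; on this read-out higher numbers stand for an effect only at larger amounts of compound and lower numbers for an effect already at smaller amounts. In this assay compound 1 gives > 27000 nM, which is a limit of the assay rather than a number. Compound 2 `O=C(Nc1ccc(-c2ccccc2)cc1)c1cc([N+](=O)[O-])ccc1Cl` gives > 27000 nM in this assay, again only a limit. Compound 3 `O=C(Nc1cccc(-c2nc3ccccc3s2)c1)c1cc([N+](=O)[O-])ccc1Cl` gives > 27000 nM in this assay, also a limit. The change from compound 1 to compound 2 is phenyl in place of 1,3-benzothiazol-2-yl on an aromatic carbon; the step that the two limits leave unreadable from compound 1 to compound 2 is not readable, since every value shown sits at the limit of > 27000 nM in this assay, at which 3 of the 3 values shown sit. How the core of compound 3 differs from the core of compound 1 is not broken down here. Compound 4 `O=C(Nc1cccc(-c2ccccc2)c1)c1cc([N+](=O)[O-])ccc1Cl` carries the change (phenyl in place of 1,3-benzothiazol-2-yl on an aromatic carbon). The place lines differ: from compound 1 to compound 2 the phenyl enters para to a large group, from compound 3 to compound 4 meta to a large group, so this is the same kind of change, not the same change. The step that the limit leaves unreadable from compound 3 to compound 4 is expected to be small, resting on (the limit of > 27000 nM in this assay, at which 3 of the 3 values shown sit). Compound 4 is expected to give about 40000 nM in this assay, most likely again only a limit, between 20000 nM and 100000 nM.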

Compound 4, half-maximal effective concentration in the BJ assay: > 27000 nM
Compound 4: only a limit was reported; the forecaster's own chance of this, stated with the estimate: 85%; the middle value lies beyond the limit too.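

In the BJ assay compound 4 gives > 27000 nM, which is a limit of the assay and not a number. In the BJ assay, compound 3 and compound 4 give no readable step, and the same holds for every other pair shown: the limit of > 27000 nM in the BJ assay, at which 4 of the 4 values shown sit.

The compounds shown leave open whether phenyl in place of 1,3-benzothiazol-2-yl changes this read-out at all, and at what concentration any of the four compounds would show an effect.

In a physicochemical assay for solubility, read by spectrophotometry, in phosphate buffer, measured as kinetic solubility, with a stated time of 18 h, at pH 7.4 (on this read-out lower numbers stand for lower solubility and higher numbers for higher solubility), compound 3 gives 580 nM and compound 4 gives 410 nM, with a 1.4-fold lower number from compound 3 to compound 4 (0.15 log units; within the scatter).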